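Chain Extension on the Shared Core: Compound 2 to Compound 3

The source may report more compounds than this note shows. Statements on the series, on what has been measured and on what is new or still open speak of the compounds shown alone.

For the measured compounds named here, in a functional assay on A549 cells (Homo sapiens) for cytotoxicity, read by MTT assay, with a stated time of 72 h (a lower number here means a stronger inhibitor, a higher number a weaker inhibitor), compound 1 `O=C1c2c[n+]([O-])c3ccccc3c2C(=O)c2c1c1ccccc1n2CCCCN1CCNCC1` gives 540 nM and compound 2 `O=C1c2c[n+]([O-])c3ccccc3c2C(=O)c2c1c1ccccc1n2CCN1CCCCC1` gives 1080 nM, so compound 2 stands within the scatter of compound 1, the only other compound measured. Compound 3 `CN1CCN(CCCCCn2c3c(c4ccccc42)C(=O)c2c[n+]([O-])c4ccccc4c2C3=O)CC1` keeps the shared core and differs from compound 2 by 3-(4-methylpiperazin-1-yl)propyl in place of piperidin-1-yl on a saturated chain carbon, two bonds along the chain from an aromatic nitrogen. Going by the values given here, the one measured step that bears on this change is a 2.0-fold higher number from compound 1 to compound 2 (0.30 log units; within the scatter), which exchanges 2-(piperazin-1-yl)ethyl for piperidin-1-yl at the same place. Compound 3 regains a six-membered non-aromatic ring with 2 hetero atoms, so a small move towards a lower number is expected in this assay, none of it clearly beyond the scatter. The expected change is a 1.7-fold lower number from compound 2 to compound 3 (0.22 log units; within the scatter). Compound 3 is estimated at 650 nM, with an expected range of 250 nM to 1700 nM.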

Compound 3, half-maximal inhibitory concentration: 870 nM
Beside the measured number, compound 3's estimate is 1.3-fold (0.13 log units) below it; the range from low to high includes it.
By their numbers in this assay, from the lowest: compounds 1, 3 and 2 (each within the scatter of the next).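

In this assay, 3-(4-methylpiperazin-1-yl)propyl in place of piperidin-1-yl on a saturated chain carbon, two bonds along the chain from an aromatic nitrogen, gives a 1.2-fold lower number from compound 2 to compound 3 (0.09 log units; within the scatter), so this larger group, with a six-membered non-aromatic ring holding 2 hetero atoms, leaves the read-out within the scatter of the smaller one. The second new comparison, (4-methylpiperazin-1-yl)methyl in place of piperazin-1-yl on a saturated chain carbon, four bonds along the chain from an aromatic nitrogen, gives a 1.6-fold higher number from compound 1 to compound 3 (0.21 log units; within the scatter). Together with the earlier step, this places all three compounds within the scatter of one another, so no change at this place has yet separated them.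

As far as these compounds go, whether a morpholine ring, a carboxylic acid or a longer chain at this place would move the number beyond the scatter remains open. No evidence is at hand on what lies behind these numbers.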